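A few compounds are considered here, and "the series" means these few. Any claim that something is new, unique, unknown or untested is made for them only; others in the source may bear on it.

Measured in a functional assay on the whole organism for inhibition, with Brassica rapa subsp. chinensis as the target, with a stated time of 3 days, tested at 100 ppm; a higher number here means more inhibition of growth at the concentration tested, a lower number less inhibition of growth:

compound 1, `Cc1ccc(OC(=O)/C=C/c2ccc(Cl)cc2Cl)c(C(C)C)c1`: 32%
compound 2, `Cc1ccc(C(C)C)c(OC(=O)/C=C/c2ccc(Cl)cc2Cl)c1`: 33%
compound 3, `Cc1ccc(OC(=O)/C=C/c2ccc(Cl)cc2)c(C(C)C)c1`: 41%

Compounds 1 and 2 have the same atoms joined differently; how the two cores differ is not broken down here. Compound 3 carries the core of compound 1 with one change, (hydrogen in place of chloro on an aromatic carbon). That step gave a number 9 percentage points higher from compound 1 to compound 3 (within the scatter), so in this assay the change is not shown to move the read-out outside the usual scatter. Compound 2 stands close to compound 1 and to compound 3, all three values lying within the scatter of one another, so no ordering among them is claimed.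

The unmeasured compound 4, `Cc1ccc(C(C)C)c(OC(=O)/C=C/c2ccc(Cl)cc2)c1`, is built on the core of compound 2 by the same change, (hydrogen in place of chloro on an aromatic carbon). Among the compounds here this change occurs twice in all, once measured and once pending. For the measured compounds named here, because the measured instance gave a number 9 percentage points higher from compound 1 to compound 3 (within the scatter), the expectation for the pending one rests on a single step on a different core, with no second measured example to check it against. The step from compound 2 to compound 4 in this assay is expected to be a number 7 percentage points higher from compound 2 to compound 4 (within the scatter), a step of the same modest size as the earlier one, with wide uncertainty because that earlier step was a number 9 percentage points higher from compound 1 to compound 3 (within the scatter) and within the scatter. For compound 4 the estimated value in this assay is 40%, with an expected range from 28% to 52%.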

Compound 4, percent growth inhibition at one concentration: 36%
For compound 4 the middle estimate is 4 percentage points above the measured one; measured number inside the range.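

In this assay, hydrogen in place of chloro on an aromatic carbon, ortho to a large group and meta to a chloro group, gives on the core of compound 2 a number 3 percentage points higher from compound 2 to compound 4 (within the scatter). Set beside the earlier step, the two instances of this change cannot be told apart: the same change on two cores in this assay, a number 9 percentage points higher (within the scatter) from compound 1 to compound 3 and a number 3 percentage points higher (within the scatter) from compound 2 to compound 4, 6 percentage points apart, within the scatter of two such steps. For the compounds shown here, this shows only that the change behaves compatibly on the two cores, with neither step leaving the usual scatter; it does not show a real effect of the change on growth inhibition that carries from core to core, since agreement between two steps this small says little, and two cores are a narrow basis for any rule.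

The compounds shown leave open whether another group on that aromatic carbon, such as a methoxy, a nitro or a trifluoromethyl group, would give a step beyond the scatter on either core. They also leave open whether removing the remaining chloro group, or replacing the ester link with an amide, would shift the read-out in this series at all.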